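Pentyl to isopentyl on the hydroxy series

The source may report more compounds than this note shows. Statements on the series, on what has been measured and on what is new or still open speak of the compounds shown alone.

Measured in a functional assay on NCI-H460 cells (Homo sapiens) for antiproliferative activity, read by MTT assay, with a stated time of 48 h; a higher number here means a weaker inhibitor, a lower number a stronger inhibitor:
- compound 1 `Cc1ccc(Nc2ccc3c(c2)C(CCC(C)C)C(=O)N3)cc1`: 55300 nM
- compound 2 `CCCCC1(O)C(=O)Nc2ccc(Nc3ccc(C)cc3)cc21`: 31800 nM
- compound 3 `CCCCCC1(O)C(=O)Nc2ccc(Nc3ccc(C)cc3)cc21`: > 100000 nM, a limit and not a number

Compound 3 stands at the limit of > 100000 nM in this assay, at which 1 of the 3 values shown sits, so no number is available for it. The next compound, compound 4 `Cc1ccc(Nc2ccc3c(c2)C(O)(CCC(C)C)C(=O)N3)cc1`, has the same atoms as compound 3, joined differently: isopropyl in place of propyl on a saturated chain carbon, two bonds along the chain from a saturated ring carbon. In full, this is pentyl to isopentyl.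

Among the measured compounds shown here, the only measured step on this chain is an at least 3.1-fold higher number from compound 2 to compound 3 (0.49 log units; beyond the scatter), which is beyond the scatter. That step adds a methyl in place of hydrogen on a saturated chain carbon, four bonds along the chain from a saturated ring carbon, so it is a different change and bears on this one only loosely. Compound 1 also carries an isopentyl chain and gives 55300 nM, which suggests a number for compound 4 within the measurable range of this assay. Another limit remains possible for compound 4. The expected step is an at least 1.6-fold lower number from compound 3 to compound 4 (0.22 log units; that floor lies within the scatter), towards a lower number and modest in size.

The estimate for compound 4 is 60000 nM, with an expected range from 25000 nM to 140000 nM.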

Compound 4, half-maximal inhibitory concentration: 22700 nM
Beside the measured number, compound 4's estimate is 2.6-fold (0.42 log units) above it; the measured number lies below the stated range.
By their numbers in this assay, from the lowest: compounds 4, 2 and 1 (each within the scatter of the next, the first and the last beyond it). At a limit, above all of these: compound 3.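

In this assay, the arrangement of the chain counts at this position, on a saturated chain carbon, two bonds along the chain from a saturated ring carbon: with the same atoms, isopropyl in place of propyl gives an at least 4.4-fold lower number from compound 3 to compound 4 (0.64 log units; beyond the scatter). The isopentyl chain also brings the hydroxy series back into the range of the butyl compound, with a 1.4-fold lower number from compound 2 to compound 4 (0.15 log units; within the scatter), and the hydroxy group on the saturated ring carbon adds a modest gain, with a 2.4-fold lower number from compound 1 to compound 4 (0.39 log units; beyond the scatter). Compound 3 is held only as a limit and not a number, so the first of these steps is a bound: the limit of > 100000 nM in this assay, at which 1 of the 4 values shown sits.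

As far as these compounds go, whether a longer chain such as isohexyl, or an amine at the chain end, holds the value of compound 4 stays open. The hydroxy step rests on a single pair, so its effect on other chains is also unsettled.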